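This account rests on a few compounds, and the source may have more. Where it says the series, first, only, none or still open, it means among the compounds named here.

Of the compounds shown here, three have been tested in a functional assay on PC-3 cells (Homo sapiens) for cytotoxicity, read by MTT assay, with a stated time of 72 h (a lower number here means a stronger inhibitor, a higher number a weaker inhibitor), and a fourth awaits measurement. Compound 1 `Cc1ccc(S(=O)(=O)c2nc3ccccc3nc2N2CCc3ccccc3C2)cc1` carries a methyl group on its outer aromatic ring and gives 22400 nM in this assay. Compound 2 `COc1ccc(S(=O)(=O)c2nc3ccccc3nc2N2CCc3ccccc3C2)cc1` differs from compound 1 by methoxy in place of methyl on an aromatic carbon. In this assay compound 2 reaches only a limit of the assay, > 50000 nM, which is the limit of > 50000 nM in this assay, at which 1 of the 3 values shown sits. The change thus produced an at least 2.2-fold higher number from compound 1 to compound 2 (0.34 log units; beyond the scatter).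

Compound 3 `Cc1ccc(S(=O)(=O)c2nc3ccccc3nc2N2CCC(O)CC2)cc1` keeps the methyl group but has a different core: it differs from compound 1 by 4-hydroxypiperidin-1-yl in place of 1,2,3,4-tetrahydroisoquinolin-2-yl on an aromatic carbon. In this assay compound 3 gives 9520 nM, the lowest number among the measured compounds, reached through a 2.4-fold lower number from compound 1 to compound 3 (0.37 log units; beyond the scatter).

Compound 4 `COc1ccc(S(=O)(=O)c2nc3ccccc3nc2N2CCC(O)CC2)cc1`, not yet measured, differs from compound 3 by methoxy in place of methyl on an aromatic carbon. This is the same change that turned compound 1 into compound 2, made at the same place, on an aromatic carbon of a six-membered aromatic ring of carbon only, para to a large group, and it occurs only that once among the measured compounds. Since that earlier step gave a higher number, a higher number is expected here as well, starting from the lower point of compound 3. Compound 4 is therefore estimated at 24000 nM in this assay. The expected step is a 2.5-fold higher number from compound 3 to compound 4 (0.40 log units; beyond the scatter). The estimate for compound 4 spans from 9500 nM to 60000 nM. On these data alone, the earlier step rests on a limit, (the limit of > 50000 nM in this assay, at which 1 of the 3 values shown sits), so its true size is unknown, and compound 4 may itself come back only as a limit.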

Compound 4, half-maximal inhibitory concentration: 9730 nM
Compound 4: the middle estimate sits 2.5-fold (0.39 log units) above what was measured, within the range that was stated.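

On the core of compound 3, methoxy in place of methyl gives a 1.0-fold higher number from compound 3 to compound 4 (0.01 log units; within the scatter), so the two compounds cannot be told apart in this assay. On these data alone, this does not show that the change behaves differently on the two cores, since the step on the core of compound 1 ends at a limit of the assay, and its true size is unknown: the same change on two cores in this assay, an at least 2.2-fold higher number (0.34 log units; beyond the scatter) from compound 1 to compound 2 and a 1.0-fold higher number (0.01 log units; within the scatter) from compound 3 to compound 4; the limit leaves it open whether they differ. The other change, 4-hydroxypiperidin-1-yl in place of 1,2,3,4-tetrahydroisoquinolin-2-yl, gives an at least 5.1-fold lower number from compound 2 to compound 4 (0.71 log units; beyond the scatter), so it points the same way with methoxy as with methyl, although a limit again leaves the comparison of sizes unsettled: the same change on two cores in this assay, a 2.4-fold lower number (0.37 log units; beyond the scatter) from compound 1 to compound 3 and an at least 5.1-fold lower number (0.71 log units; beyond the scatter) from compound 2 to compound 4; the limit leaves it open whether they differ.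

The compounds shown cover only methyl and methoxy at this place on the outer ring, which leaves open how a chlorine atom, a carboxylic acid or an amine there would read in this assay. As far as these compounds go, it also remains open whether an open-chain amine with a longer chain, in place of 4-hydroxypiperidin-1-yl, would give a lower number in this assay.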